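Replacing the Benzofuran Amide with an Acetylated Aliphatic Chain

This account rests on a few compounds, and the source may have more. Where it says the series, first, only, none or still open, it means among the compounds named here.

Compound 3 `CN(C)CCCOc1ccc(CN2CC[C@H](NC(=O)c3cc4ccccc4o3)C2)cc1` gives 2510 nM in an assay on HEK293 cells for binding affinity to Urotensin-2 receptor (Homo sapiens), read by radioligand binding (a lower number here means a stronger inhibitor, a higher number a weaker inhibitor), the highest of the two numbers obtained; compound 1 `Cc1cc(C(=O)N[C@H]2CCN(Cc3ccc(OCCCN(C)C)cc3)C2)ccc1Br` gives 631 nM. Going by the values given here, the step of a 4.0-fold higher number from compound 1 to compound 3 (0.60 log units; beyond the scatter) is the only measured step available. For compound 2 `CN(C)CCCOc1ccc(CN2CC[C@H](NC(=O)c3ccc(-c4ccccc4)cc3)C2)cc1` this assay returned only a limit, < 10000 nM (the limit of < 10000 nM in this assay, at which 1 of the 3 values shown sits). Compound 4 `CC(=O)N[C@@H](CC(C)C)C(=O)N[C@H]1CCN(Cc2ccc(OCCCN(C)C)cc2)C1` differs from compound 3 by 1-acetamido-3-methylbutyl in place of 1-benzofuran-2-yl on a carbonyl carbon, so the carbonyl now carries an open chain bearing its own amide instead of a fused aromatic ring. The step from compound 1 to compound 3 bears on this only loosely, as it exchanged one aromatic group for another, whereas here the aromatic group is removed altogether. One therefore expects a further weakening beyond the scatter, estimated as a 2.8-fold higher number from compound 3 to compound 4 (0.45 log units; beyond the scatter). The estimate for compound 4 is 7000 nM, within a range of 2500 nM to 25000 nM.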

Compound 4, inhibition constant: 2510 nM
For compound 4 the middle estimate is 2.8-fold (0.45 log units) above the measured one; low and high end bracket the measured number.
By their numbers in this assay, from the lowest: compound 1; then compounds 3 and 4 (each within the scatter of the next).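

In this assay, the result from the ring-free 1-acetamido-3-methylbutyl group is no change at the digits printed from compound 3 to compound 4 (within the scatter), so on this carbonyl carbon the 1-benzofuran-2-yl rings can be given up without a measurable loss. The open chain still gives a 4.0-fold higher number from compound 1 to compound 4 (0.60 log units; beyond the scatter), leaving it short of the 4-bromo-3-methylphenyl group. Compound 2 gives only a limit, so it cannot be placed in this order: the limit of < 10000 nM in this assay, at which 1 of the 4 values shown sits.

The compounds shown leave open whether a free amine in place of the acetamido group would hold this level. Going by these compounds, whether a straight chain could replace the branched one also remains open.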